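The compounds below may be only part of what the source reports. "The series", "measured", "known", "first", "only" and "open" are said of these compounds alone.

Working notes on the series. Of the compounds shown here, three on the shared core have been measured: compound 1 `Cn1c(-c2ccc(C(=O)NC3CC3)cc2)nnc1C1(c2ccc(Cl)cc2)CCC1`, compound 2 `CC(=O)Nc1ccc(-c2nnc(C3(c4ccc(Cl)cc4)CCC3)n2C)c(Cl)c1` and compound 3 `Cn1c(-c2ccc(-c3cnccn3)cc2F)nnc1C1(c2ccc(Cl)cc2)CCC1`. In an assay on isolated protein for inhibition of 11-beta-hydroxysteroid dehydrogenase type 2 (Mus musculus) (on this read-out lower numbers stand for stronger inhibition and higher numbers for weaker inhibition), compound 1 reaches only a limit, > 4000 nM. In this assay compound 2 likewise gives a limit and no number, > 4000 nM. Compound 3 also sits at a limit, > 4000 nM. All three values stand at the limit of > 4000 nM in this assay, at which 3 of the 3 values shown sit, so compound 2 is not set apart from either neighbour on the numbers shown. Compound 4 `Cn1c(-c2ccc(C(=O)O)cc2Cl)nnc1C1(c2ccc(Cl)cc2)CCC1` differs from compound 2 by carboxy in place of acetamido on an aromatic carbon. For the measured compounds named here, no step between two measured compounds is available, so no direction can be read from the data; the expectation is no step beyond the scatter. Compound 4 is expected to give about 8000 nM in this assay, between 3000 nM and 30000 nM. That estimate means a step from compound 2 to compound 4 of a step that the limit leaves unreadable from compound 2 to compound 4, expected to stay within the scatter and most likely to be reported again only as a limit.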

Compound 4, half-maximal inhibitory concentration: > 4000 nM
Compound 4: a limit, no number; the forecaster's own chance of this, stated with the estimate: 85%; the middle value lies beyond the limit too.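

Compound 2 and compound 4 are both reported only as limits, so no step between them can be read: the limit of > 4000 nM in this assay, at which 4 of the 4 values shown sit.

The compounds shown leave open whether any change on the shared core gives a measurable number in this assay.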